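The compounds below may be only part of what the source reports. "The series", "measured", "known", "first", "only" and "open" are said of these compounds alone.

Three compounds sharing one core have numbers in a functional assay on OVCAR-3 cells (Homo sapiens) for inhibition, read by sulforhodamine B assay, with a stated time of 48 h; on this read-out lower numbers stand for stronger inhibition of growth and higher numbers for weaker inhibition of growth. Compound 1 `CCOC(=O)c1nn(-c2ccccc2)c(-c2ccc([N+](=O)[O-])cc2)c1CNC(C)(C)C` gives 8780 nM; 288000 nM (2 entries), entries that lie far apart. Compound 2 `CCOC(=O)c1nn(-c2ccc(Cl)cc2)c(-c2ccc(F)cc2)c1CNC(C)(C)C` gives 159000 nM; > 537000 nM (2 entries). Going by the values given here, compound 3 `CC(C)(C)NCc1c(C(=O)O)nn(-c2ccc(Cl)cc2)c1-c1ccc(F)cc1` gives 116000 nM, the only single number among the three, and it falls inside the span of the entries of compound 1.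

Compound 4 `Cc1ccc(-c2c(CNC(C)(C)C)c(C(=O)O)nn2-c2ccc(Cl)cc2)cc1` departs from compound 3 at one place: methyl in place of fluoro on an aromatic carbon. The change lies para to a large group, so that 4-fluorophenyl becomes 4-methylphenyl.

Among the compounds with values here, no measured pair of compounds differs in a single place, so the data give no direct size for this change. In this assay no step beyond the usual scatter is expected, and the expectation therefore starts from compound 3 at 116000 nM. The range has to stay wide, as the several entries of compound 1 in this assay, 8780 nM; 288000 nM (2 entries) and the several entries of compound 2 in this assay, 159000 nM; > 537000 nM (2 entries) show how far entries for one compound can part here. The expected change, a 1.1-fold lower number from compound 3 to compound 4 (0.02 log units; within the scatter), is estimated to remain within the scatter. For compound 4 the estimated value is 110000 nM, with an expected range from 30000 nM to 400000 nM.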

Compound 4, concentration for 50% growth inhibition: > 629000 nM
Compound 4: only a limit was reported; the forecaster's own chance of this, stated with the estimate: 25%; at least 5.7-fold (0.75 log units) between middle value and limit.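

Going by these compounds alone, the change from 4-fluorophenyl to 4-methylphenyl, methyl in place of fluoro on an aromatic carbon para to a large group, supplies the first single-place step in this assay: an at least 5.4-fold higher number from compound 3 to compound 4 (0.73 log units; beyond the scatter). Within the data shown here, this shows that growth inhibition is not indifferent to which of these two groups sits at this position, something that the three earlier compounds, with no single-place pair among them, could not show. Compound 4 gives > 629000 nM, which is a limit of the assay and not a number, so the step has a lower bound but no known full size, and it needs caution since entries for one compound can part widely in this assay: the several entries of compound 1 in this assay, 8780 nM; 288000 nM (2 entries)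

The compounds shown leave open whether a chloro, a methoxy or an amine at this position would stay close to compound 3 or move the number as methyl does. They also leave open whether the same change would give a similar step with the ethyl ester that compound 2 carries in place of the carboxylic acid.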